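Opening the Ring on the Core of Compound 1

The source may report more compounds than this note shows. Statements on the series, on what has been measured and on what is new or still open speak of the compounds shown alone.

Measured compounds:
compound 1 `COc1c(N2CC[C@@H](N)C2)c(F)cc2c(=O)c(C(=O)O)cn(Cc3ccc(-c4ccccc4)cc3)c12` — 92200 nM
compound 2 `O=C(O)c1cn(Cc2ccc(-n3cccn3)cc2)c2cc(NC[C@H]3CCNC3)c(F)cc2c1=O` — 187000 nM
compound 3 `O=C(O)c1cn(Cc2ccc(-n3cccn3)cc2)c2cc(NC[C@@H]3CCNC3)c(F)cc2c1=O` — 200000 nM

In an assay on isolated protein for inhibition of DNA topoisomerase 1 (Homo sapiens), with a stated time of 15 min (a lower number here means a stronger inhibitor, a higher number a weaker inhibitor), compound 1 gives the lowest of the three numbers, so it is the strongest inhibitor of this small set, with compound 2 and compound 3 both clearly above it. Those two differ from each other only in how one stereocentre is drawn, and a 1.1-fold higher number from compound 2 to compound 3 (0.03 log units; within the scatter) shows that this configuration makes no difference that can be trusted, because of the fact that compounds 2 and 3 differ only in the configuration as drawn.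

Compound 4 `CNCCNc1c(F)cc2c(=O)c(C(=O)O)cn(Cc3ccc(-c4ccccc4)cc3)c2c1OC` is not yet measured. It differs from compound 1 by (2-(methylamino)ethyl)amino in place of 3-aminopyrrolidin-1-yl on an aromatic carbon, an open chain taking the place of a five-membered ring on the aromatic carbon of the shared core. For the measured compounds named here, no measured pair changes a ring for a chain, so nothing measured bears directly on this step; the one measured step concerns configuration only. Compound 4 is therefore expected to give about 120000 nM, in the range 40000 nM to 350000 nM. That estimate means an expected 1.3-fold higher number from compound 1 to compound 4 (0.11 log units; within the scatter), a step not beyond the scatter.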

Compound 4, half-maximal inhibitory concentration: > 200000 nM
Compound 4: a limit, no number; the forecaster's own chance of this, stated with the estimate: 20%; middle value at least 1.6-fold (0.22 log units) away from the limit.
By their numbers in this assay, from the lowest: compound 1; then compounds 2 and 3 (each within the scatter of the next).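

In this assay compound 4 gives a limit of the assay, not a number (> 200000 nM). For the compounds shown here, at this position on the aromatic carbon, ortho to a fluoro group and ortho to a methoxy group, the earlier compounds showed nothing about the side group itself, and putting the open chain (2-(methylamino)ethyl)amino in place of the 3-aminopyrrolidin-1-yl ring weakens inhibition beyond the scatter (an at least 2.1-fold higher number from compound 1 to compound 4 (0.33 log units; beyond the scatter)). How much weaker compound 4 truly is cannot be told, because its reading gives only a lower bound: the limit of > 200000 nM in this assay, at which 1 of the 4 values shown sits.

As far as these compounds go, whether a longer chain such as (3-(methylamino)propyl)amino or a six-membered piperazin-1-yl ring would behave like compound 1 or like compound 4 stays open. Also open, from the compounds shown here alone, is whether the mirror-image 3-aminopyrrolidin-1-yl group would match compound 1.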